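The compounds below may be only part of what the source reports. "The series", "measured", "known", "first", "only" and "open" are said of these compounds alone.

Measured compounds so far:
- compound 1 `C[C@@H](Cn1ccc(-c2ccc(C#N)c(Cl)c2)n1)NC(=O)c1ccccc1`: 1830 nM
- compound 2 `C[C@@H](Cn1ccc(-c2ccc(C#N)c(Cl)c2)n1)NC(=O)c1cccc(OCC(O)CO)c1`: 740 nM
- compound 3 `CC(=O)c1ccc(S(=O)(=O)N[C@@H](C)Cn2ccc(-c3ccc(C#N)c(Cl)c3)n2)cc1`: 5230 nM

In a functional assay on LNCaP cells (Homo sapiens) for antiproliferative activity, read by CCK-8 assay, with a stated time of 6 days (a higher number here means a weaker inhibitor, a lower number a stronger inhibitor), compound 1 gives 1830 nM, which places it second highest of the three numbers. Its nearest neighbour is compound 2, where the change from compound 1 to compound 2 is a 2.5-fold lower number from compound 1 to compound 2 (0.39 log units; beyond the scatter), a modest step brought by 2,3-dihydroxypropoxy in place of hydrogen on an aromatic carbon. Among the measured compounds shown here, compound 3 carries a sulfonamide rather than the amide of compound 1 and gives the highest number of the set; no single-point step links it to compound 1, so only the two values themselves can be compared.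

The next compound, compound 4 `C[C@@H](Cn1ccc(-c2ccc(C#N)c(Cl)c2)n1)Nc1ccccc1`, differs from compound 1 by phenyl in place of benzoyl on an amine nitrogen. For the measured compounds named here, none of the measured steps bears on this change: the only step on record alters a substituent on the benzoyl ring, not the linkage itself, and compound 3 changes the linkage in a different way. The higher number of compound 3 is the only hint that altering the amide is unlikely to help. The expectation for compound 4 is therefore a step of a 2.2-fold higher number from compound 1 to compound 4 (0.34 log units; beyond the scatter), towards a weaker inhibitor, with wide uncertainty. Compound 4 is estimated at 4000 nM, in the range 1200 nM to 15000 nM.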

Compound 4, half-maximal inhibitory concentration: 710 nM
Compound 4: the middle estimate sits 5.6-fold (0.75 log units) above what was measured; the whole stated range lies above it.
By their numbers in this assay, from the lowest: compounds 4 and 2 (each within the scatter of the next); then compound 1; then compound 3.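

In this assay, among the compounds shown here, a 2.6-fold lower number from compound 1 to compound 4 (0.41 log units; beyond the scatter) is the first step that alters the linkage on the amine nitrogen itself, since the earlier step only added a substituent to the benzoyl ring. The carbonyl of the benzoyl group is therefore not needed for antiproliferative activity in this pair: with phenyl directly on the amine nitrogen, the hydrogen-bond acceptor counted on the benzoyl group is gone, yet the number still falls. Nothing measured here accounts for this step.

Going by these compounds, it remains open whether the 2,3-dihydroxypropoxy group, which gave the lower number in compound 2, would lower the number further on the phenyl ring of compound 4, and whether an amine or a carboxylic acid on that ring would do the same. Also open, on these data alone, is how much the distance between the amine nitrogen and the ring matters, for example with benzyl on that nitrogen in place of phenyl, since this single pair fixes only one direct attachment.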